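This account rests on a few compounds, and the source may have more. Where it says the series, first, only, none or still open, it means among the compounds named here.

Measured so far in a functional assay on SMMC-7721 cells (Homo sapiens) for antiproliferative activity, read by MTT assay, with a stated time of 48 h; a higher number here means a weaker inhibitor, a lower number a stronger inhibitor:
- Compound 1 `CN(C)CCCn1nc(C2=C(c3cn(C)c4ccccc34)C(=O)NC2=O)c2cccnc21`: > 100000 nM
- Compound 2 `Cn1cc(C2=C(c3n[nH]c4ncccc34)C(=O)NC2=O)c2ccccc21`: > 100000 nM

Both entries are limits of the assay, not numbers. Compound 2 stands at the limit of > 100000 nM in this assay, at which 2 of the 2 values shown sit.

Compound 3 `Cn1cc(C2=C(c3nn(CCCCn4ccnc4)c4ncccc34)C(=O)NC2=O)c2ccccc21` has 4-(1H-imidazol-1-yl)butyl in place of hydrogen on an aromatic nitrogen. Within the data shown here, the one measured step that bears on this swap is a step that the two limits leave unreadable from compound 1 to compound 2. It gives no size and no direction to carry over, so only a cautious expectation is possible: compound 3 should remain a weak inhibitor in this assay, and it may well stay at the limit. The expected change is an at least 1.6-fold lower number from compound 2 to compound 3 (0.22 log units; that floor lies within the scatter). The estimate for compound 3 is 60000 nM, with an expected range from 10000 nM to 200000 nM.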

Compound 3, half-maximal inhibitory concentration: 29200 nM
For compound 3 the middle estimate is 2.1-fold (0.31 log units) above the measured one, within the range that was stated.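

Compound 1 and compound 2 both rest on a limit of the assay, not a number: the limit of > 100000 nM in this assay, at which 2 of the 3 values shown sit. In this assay, putting 4-(1H-imidazol-1-yl)butyl on this aromatic nitrogen gives the first readable change, an at least 3.4-fold lower number from compound 2 to compound 3 (0.53 log units; beyond the scatter). The comparison with the chain-bearing compound 1 gives an at least 3.4-fold lower number from compound 1 to compound 3 (0.53 log units; beyond the scatter), and each of these two steps sets only a floor on the size of the change. As far as these compounds go, what stays open is whether the 1H-imidazol-1-yl ring or the chain carrying it matters more, and how a longer chain or a morpholine at the chain end would read.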